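Removing the 3-methylbut-2-en-1-yl chain from compound 1

The compounds below may be only part of what the source reports. "The series", "measured", "known", "first", "only" and "open" are said of these compounds alone.

Measured in a functional assay on HeLa cells (Homo sapiens) for inhibition, read by MTT assay, with a stated time of 72 h; on this read-out lower numbers stand for stronger inhibition and higher numbers for weaker inhibition:
compound 1 `COc1cc(O)c(CC=C(C)C)c(O)c1C(=O)/C=C/c1ccc([N+](=O)[O-])cc1`: 29700 nM
compound 2 `COc1cc(O)c(CC=C(C)C)c(O)c1C(=O)/C=C/c1ccc(C(F)(F)F)cc1`: 6800 nM
compound 3 `COc1cc(O)c(CC=C(C)C)c(O)c1C(=O)/C=C/c1cccc([N+](=O)[O-])c1`: 16500 nM
compound 4 `COc1cc(O)cc(O)c1C(=O)/C=C/c1ccc([N+](=O)[O-])cc1`: not yet measured

Compound 1 stands at the high end of these numbers, the end of weaker inhibition. Putting trifluoromethyl in place of nitro gives a 4.4-fold lower number from compound 1 to compound 2 (0.64 log units; beyond the scatter). Putting 3-nitrophenyl in place of 4-nitrophenyl gives a 1.8-fold lower number from compound 1 to compound 3 (0.26 log units; within the scatter).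

Compound 4 changes a different part of the molecule: hydrogen in place of 3-methylbut-2-en-1-yl on an aromatic carbon. Neither measured step touches this aromatic carbon, so the two steps offer only a rough scale of size and no direction. Among the measured compounds shown here, no measured pair shows what this chain contributes. A modest step towards a higher number is expected in this assay, although a step within the scatter would be no surprise. The expected step is a 1.3-fold higher number from compound 1 to compound 4 (0.13 log units; within the scatter). For compound 4 the estimated value is 40000 nM, with an expected range from 14000 nM to 100000 nM.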

Compound 4, half-maximal inhibitory concentration: > 50000 nM
Compound 4 gave a limit, no number (the forecaster's own chance of this, stated with the estimate: 25%); at least 1.2-fold (0.09 log units) between middle value and limit.
By their numbers in this assay, from the lowest: compound 2; then compounds 3 and 1 (each within the scatter of the next). At a limit, above all of these: compound 4.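

In this assay, among the compounds shown here, the earlier steps touched only the nitro group and its place, so this is the first reading of what the 3-methylbut-2-en-1-yl chain contributes. Hydrogen in place of that chain gives an at least 1.6-fold higher number from compound 1 to compound 4 (0.22 log units; that floor lies within the scatter) and so brings no lower number, though this floor alone cannot separate a small step from a large one. Compound 4 gives a limit of the assay and not a number, so the full size of the step stays unknown: the limit of > 50000 nM in this assay, at which 1 of the 4 values shown sits.

Still open, as far as these compounds go, is whether a methyl group, a longer chain such as pentyl, or a hydroxy group on this aromatic carbon would keep the number of compound 1 or move it. Also open, from the compounds shown here alone, is whether taking the chain away from compound 2, which carries trifluoromethyl, would give a step of similar size.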